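Trifluoromethyl in Place of Methylsulfanyl: Solubility of Compound 3

The source may hold more compounds than are shown below. What is called first, only, known or untested is meant among the compounds shown, and "the series" means these compounds.

Measured so far:
compound 1, `CSc1ccc(NC(=O)Nc2cc(C)nc3ccccc23)cc1`: 1300 nM
compound 2, `Cc1cc(NC(=O)Nc2ccccc2C(N)=O)c2ccccc2n1`: 200 nM

Two ureas on a shared core have been measured in a physicochemical assay for solubility, at pH 7.4; on this read-out higher numbers stand for higher solubility and lower numbers for lower solubility. Compound 1 gives 1300 nM, the higher of the two numbers; compound 2 gives 200 nM, and the gap between them lies beyond the scatter. Among the compounds with values here, the two measured compounds do not differ in a single place, so no step between measured compounds can be read off, and the pair shows only its two values.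

Compound 3, `Cc1cc(NC(=O)Nc2ccc(C(F)(F)F)cc2)c2ccccc2n1`, is not yet measured. It differs from compound 1 in one place: trifluoromethyl in place of methylsulfanyl on an aromatic carbon. Within the data shown here, with no measured step of this kind to lean on, a modest downward step in this assay is expected, a 2.2-fold lower number from compound 1 to compound 3 (0.34 log units; beyond the scatter), one that may or may not clear the scatter. The estimate for compound 3 is 600 nM, within a range from 150 nM to 2500 nM.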

Compound 3, solubility: 100 nM
Beside the measured number, compound 3's estimate is 6.0-fold (0.78 log units) above it; measured number below the stated range.
By their numbers in this assay, from the lowest: compounds 3 and 2 (each within the scatter of the next); then compound 1.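

In this assay, trifluoromethyl in place of methylsulfanyl on an aromatic carbon, para to a large group, gives a 13-fold lower number from compound 1 to compound 3 (1.11 log units; beyond the scatter) and counts as a large step. Within the data shown here, it is the first step in this set that can be read at a single place, since the two earlier compounds differ in more than one place and offered only two separate values. It shows that the read-out is sensitive to the group at this position, although no measurement at hand bears on why the step is so large.

This single step cannot separate what is lost with methylsulfanyl from what is gained with trifluoromethyl. On these data alone, how an amine, a carboxylic acid or a longer chain at the same position would read also remains open.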